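Compound 4 and the Limit of the Assay

This account rests on a few compounds, and the source may have more. Where it says the series, first, only, none or still open, it means among the compounds named here.

In a functional assay on BGC-823 cells (Homo sapiens) for inhibition, read by MTT assay, with a stated time of 72 h (on this read-out higher numbers stand for weaker inhibition and lower numbers for stronger inhibition), compound 1 (`Cc1cc(N2CC[C@@H](C)[C@@H](N(C)c3ncnc4[nH]ccc34)C2)n2ncnc2n1`) gives 67400 nM. Compound 2 (`Cc1cc(N2CC[C@@H](C)[C@@H](N(C)c3ncnc4[nH]ccc34)C2)n2nc(SCc3nc4ccccc4[nH]3)nc2n1`), which carries ((1H-benzimidazol-2-yl)methyl)sulfanyl, reads > 100000 nM, and this is a limit of the assay. Compound 3 (`Cc1cc(N2CC[C@@H](C)[C@@H](N(C)c3ncnc4[nH]ccc34)C2)n2nc(SCc3csc4ccc(Cl)cc34)nc2n1`), which carries ((5-chloro-1-benzothiophen-3-yl)methyl)sulfanyl, reads > 100000 nM, which is likewise a limit and not a number. The measured steps offer little to build on. They show an at least 1.4-fold higher number from compound 1 to compound 2 (0.17 log units; that floor lies within the scatter) and an at least 1.4-fold higher number from compound 1 to compound 3 (0.17 log units; that floor lies within the scatter), and there is also a step that the two limits leave unreadable from compound 2 to compound 3.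

Compound 4 (`Cc1cc(N2CC[C@@H](C)[C@@H](N(C)c3ncnc4[nH]ccc34)C2)n2nc(SCc3ccc(F)cc3)nc2n1`) differs from compound 3 in one place, on a saturated chain carbon bound to a sulfur, where 4-fluorophenyl stands in place of 5-chloro-1-benzothiophen-3-yl (4-fluorophenyl in place of 5-chloro-1-benzothiophen-3-yl on a saturated chain carbon bound to a sulfur). Two different groups at this place, in compound 2 and compound 3, both end at the limit of > 100000 nM in this assay, at which 2 of the 3 values shown sit, so no step beyond the scatter is expected from this change. The expected step is an at least 1.1-fold lower number from compound 3 to compound 4 (0.04 log units; that floor lies within the scatter). Compound 4 may well be reported only as a limit again. For compound 4 the estimated value is 90000 nM, with an expected range from 40000 nM to 200000 nM.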

Compound 4, half-maximal inhibitory concentration: 44300 nM
Compound 4: middle estimate off by 2.0-fold (0.31 log units), on the high side; measured number inside the range.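

At the place on a saturated chain carbon bound to a sulfur, the group now makes a readable difference in this assay: the change to 4-fluorophenyl gives an at least 2.2-fold lower number from compound 3 to compound 4 (0.35 log units; beyond the scatter), and it gives an at least 2.2-fold lower number from compound 2 to compound 4 (0.35 log units; beyond the scatter). Compound 2 and compound 3 each remain at a limit of the assay and not at a number: the limit of > 100000 nM in this assay, at which 2 of the 4 values shown sit. A group on the sulfur therefore need not end at that limit, for (4-fluorobenzyl)sulfanyl in place of hydrogen on an aromatic carbon gives only a 1.5-fold lower number from compound 1 to compound 4 (0.18 log units; within the scatter), which leaves compound 4 level with compound 1.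

The full size of the first two steps stays open, as each rests on a limit and gives only a floor, and the three groups shown do not tell whether the fluorine, the single carbon-only ring or something else separates compound 4 from the other two. Also open, from the compounds shown here alone, is whether a plain phenyl, a 4-methoxyphenyl or a chain ending in an amine at this place would give a number that moves beyond the scatter from compound 1.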